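Allyl for 1,1-dimethylprop-2-en-1-yl in a limit-bound series

A few compounds are considered here, and "the series" means these few. Any claim that something is new, unique, unknown or untested is made for them only; others in the source may bear on it.

Compound 1 `C=CCc1cc(-c2ccc(OC)cc2)cc(CC=C)c1O` gives > 100000 nM as a limit
Compound 2 `C=CCOc1ccc(-c2ccc(OC)cc2)cc1CC=C` gives > 100000 nM as a limit
Compound 3 `C=CC(C)(C)c1cc(-c2ccc(OC)cc2)ccc1O` gives > 100000 nM as a limit

All three were read in a functional assay on HUVEC cells (Homo sapiens) for antiproliferative activity, read by MTT assay, with a stated time of 24 h (a higher number here means a weaker inhibitor, a lower number a stronger inhibitor), and none yields a number. Compound 3 sits at the limit of > 100000 nM in this assay, at which 3 of the 3 values shown sit, and so has only a limit. Compound 4 `C=CCc1cc(-c2ccc(OC)cc2)ccc1O` carries allyl in place of 1,1-dimethylprop-2-en-1-yl on an aromatic carbon, ortho to a hydroxy group allyl in place of 1,1-dimethylprop-2-en-1-yl on an aromatic carbon in this series. Among the measured compounds shown here, no measured step is available to size this change. The expectation rests on compound 1, which carries allyl and gives > 100000 nM as a limit. In this assay the expected a number no higher from compound 3 to compound 4 (the limit leaves the size open) is small, with no clear direction. For compound 4 the estimate is 100000 nM with an expected range from 40000 nM to 200000 nM and a real chance of only a limit.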

Compound 4, half-maximal inhibitory concentration: > 100000 nM
Compound 4 was reported as a limit; the forecaster's own chance of this, stated with the estimate: 60%; the middle value lies on the limit itself.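

No step can be read between compound 4 and compound 1, compound 2 or compound 3, because all four share one limit: the limit of > 100000 nM in this assay, at which 4 of the 4 values shown sit. The compounds shown leave open how far apart they lie in this assay and whether any change on the shared core gives a measurable value.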